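Swapping the ketone aryl group in a hydroxamic acid series

A few compounds are considered here, and "the series" means these few. Any claim that something is new, unique, unknown or untested is made for them only; others in the source may bear on it.

Of the compounds shown here, three have been measured in an assay on isolated protein for inhibition of protein deacetylase HDAC6 (Homo sapiens); a lower number here means a stronger inhibitor, a higher number a weaker inhibitor. Compound 1 `COc1cc(C(=O)c2ccc3c(ccn3S(=O)(=O)c3ccc(/C=C/C(=O)NO)cc3)c2)cc(OC)c1OC` gives 972 nM. Compound 3 `O=C(/C=C/c1cccc(S(=O)(=O)n2ccc3cc(C(=O)c4ccc(F)cc4)ccc32)c1)NO` gives 1420 nM. Compound 2 `O=C(NO)c1ccc(Cn2ccc3cc(C(=O)c4ccc(F)cc4)ccc32)cc1` gives 9.25 nM, the lowest of the three numbers; its gap to compound 1 and to compound 3 lies well beyond the scatter of repeated measurements, so compound 2 is the strongest inhibitor of the set.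

Compound 4 `COc1cccc(C(=O)c2ccc3c(ccn3Cc3ccc(C(=O)NO)cc3)c2)c1` has not yet been measured. It differs from compound 2 in one place: 3-methoxyphenyl in place of 4-fluorophenyl on a carbonyl carbon. The hydroxamic acid, the linker and the shared core of compound 2 are kept unchanged; only the aryl group on the carbonyl carbon is exchanged.

For the measured compounds named here, no measured pair in this set shows what such an exchange does, so the expectation rests on compound 2 alone, whose value of 9.25 nM is the starting point. The change sits on the carbonyl carbon and leaves the hydroxamic acid side untouched. The step is expected to be small, at most a modest loss that may well fall within the scatter, and is estimated at a 1.3-fold higher number from compound 2 to compound 4 (0.11 log units; within the scatter). Compound 4 is therefore expected to give about 12 nM in this assay, with a plausible range from 4 nM to 35 nM.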

Compound 4, half-maximal inhibitory concentration: 16.4 nM
Compound 4: the middle estimate sits 1.4-fold (0.14 log units) below what was measured; the measured number falls inside the stated range.
By their numbers in this assay, from the lowest: compounds 2 and 4 (each within the scatter of the next); then compounds 1 and 3 (each within the scatter of the next).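

In this assay, for the compounds shown here, the exchange of 4-fluorophenyl for 3-methoxyphenyl on the carbonyl carbon gives a 1.8-fold higher number from compound 2 to compound 4 (0.25 log units; within the scatter), the first step in this set that can be read at this position. The position therefore takes an aryl group with a different substituent, one more heavy atom and a hydrogen-bond acceptor, without a step beyond the scatter, so this single exchange separates the two aryl groups by no measurable amount on the shared core and with the hydroxamic acid and linker of compound 2. No measurement offered here accounts for how closely the two aryl groups agree.

This is one exchange between two aryl groups, so it leaves open whether the position would stay as tolerant of a 4-methoxyphenyl group, a pyridine ring, or a phenyl ring carrying an amine or a carboxylic acid. It also leaves open whether the fluorine or the methoxy group contributes anything at all, which a plain unsubstituted phenyl group on the same carbonyl carbon would begin to answer.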